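Furanyl acrylonitrile amides against colon carcinoma cells

This account rests on a few compounds, and the source may have more. Where it says the series, first, only, none or still open, it means among the compounds named here.

Measured so far:
compound 1, `N#C/C(=C\c1ccc([N+](=O)[O-])cc1)C(=O)c1c[nH]c2ccccc12`, 41000 nM
compound 2, `N#C/C(=C\c1ccco1)C(=O)NCc1ccc(Cl)c(Cl)c1`, 20000 nM
compound 3, `COc1ccc(CNC(=O)/C(C#N)=C/c2ccc(C)o2)cc1`, 92000 nM

In a functional assay on HT-29 cells (Homo sapiens) for inhibition, read by MTT assay, with a stated time of 72 h (a higher number here means a weaker inhibitor of growth, a lower number a stronger inhibitor of growth), compound 3 gives 92000 nM, the highest of the three numbers, with compound 1 nearest and compound 2 furthest, both gaps lying beyond the scatter. Compound 4, `COc1ccc(CNC(=O)/C(C#N)=C/c2ccoc2)cc1`, differs from compound 3 by furan-3-yl in place of 5-methylfuran-2-yl on a double-bonded chain carbon bound to a double-bonded chain carbon. Among the measured compounds shown here, no measured pair shows this change alone, so no step of known size supports a prediction. Compound 2, which also carries a furan ring on that carbon, gives 20000 nM, but it differs from compound 3 in two places, so only its value can be noted. For compound 4 a modest step downward, not clearly beyond the scatter, is expected, a 1.3-fold lower number from compound 3 to compound 4 (0.12 log units; within the scatter). Compound 4 is thus estimated at 70000 nM, within 25000 nM to 200000 nM.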

Compound 4, concentration for 50% growth inhibition: 6000 nM
Estimate against measurement, compound 4: 12-fold (1.07 log units) above, and the stated range ends above it.
By their numbers in this assay, from the lowest: compound 4; then compound 2; then compound 1; then compound 3.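

In this assay, the group on a double-bonded chain carbon bound to a double-bonded chain carbon proves to matter strongly: furan-3-yl in place of 5-methylfuran-2-yl gives a 15-fold lower number from compound 3 to compound 4 (1.19 log units; beyond the scatter). The two groups each hold one five-membered aromatic ring with one hetero atom and have the same hydrogen-bond donor and acceptor counts, yet the number moves this far. Nothing at hand explains the step. The change removes the methyl group and alters the furan attachment together, and the compounds shown do not separate the two. Going by these compounds, whether thiophen-3-yl on that carbon would keep the lower number also stays open.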